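Methyl for cyano on the fused core of compound 2

A few compounds are considered here, and "the series" means these few. Any claim that something is new, unique, unknown or untested is made for them only; others in the source may bear on it.

Notes on the series. Compound 2 `C[C@@H]1CC(c2cnc3c(C#N)nn([C@H](C)c4ccc(Cl)cc4Cl)c3n2)=CC[C@@H]1N1CCC[C@H]1CO` gives 40 nM in a functional assay on cells for antagonist activity at C-C chemokine receptor type 4 (Homo sapiens), read by fluorescence and calcium flux, with stated times of 2.5 s and 45 s (on this read-out higher numbers stand for weaker inhibition and lower numbers for stronger inhibition), the lowest of the three numbers in hand. Compound 1 `Cc1nn(C(C)c2ccc(Cl)cc2Cl)c2nc(N3CCC(N4CCCCC4)C(C)C3)cnc12` gives 126 nM in this assay; compound 1 differs from compound 2 in more than one place, so the two values stand side by side without a single-change step between them. Within the data shown here, compound 3 `C[C@@H]1CC(c2cnc3c(C#N)nn([C@H](C)c4ccc(Cl)cc4Cl)c3n2)=CC[C@@H]1N1CCC[C@H]1C(C)(C)O` gives 384 nM in this assay; the one single-change step recorded, a 9.6-fold higher number from compound 2 to compound 3 (0.98 log units; beyond the scatter), concerns the substituent on the saturated ring and not the fused core.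

Compound 4 `Cc1nn([C@H](C)c2ccc(Cl)cc2Cl)c2nc(C3=CC[C@H](N4CCC[C@H]4CO)[C@H](C)C3)cnc12` is not yet measured. It differs from compound 2 by methyl in place of cyano on an aromatic carbon. Among the measured compounds shown here, no measured step exchanges a group on the fused core, so the size of this change has no direct precedent; the only recorded step, a 9.6-fold higher number from compound 2 to compound 3 (0.98 log units; beyond the scatter), lies elsewhere in the molecule. Compound 1 carries the same methyl on its core and gives 126 nM, which argues against a large loss. A modest step is expected for compound 4, a 2.0-fold higher number from compound 2 to compound 4 (0.30 log units; within the scatter), with either direction possible but a lean toward weaker inhibition. Compound 4 is estimated at 80 nM, with a range of 25 nM to 250 nM.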

Compound 4, half-maximal inhibitory concentration: 36 nM
Compound 4: middle estimate off by 2.2-fold (0.35 log units), on the high side, within the range that was stated.
By their numbers in this assay, from the lowest: compounds 4 and 2 (each within the scatter of the next); then compound 1; then compound 3.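

In this assay, among these compounds, the exchange of cyano for methyl on an aromatic carbon of the five-membered aromatic ring gives a 1.1-fold lower number from compound 2 to compound 4 (0.05 log units; within the scatter) and is the first single-change step read on the fused core. At this position, the two groups give numbers that cannot be told apart, even though cyano carries a triple bond and a hydrogen-bond acceptor that methyl does not. Nothing measured here explains this result.

Among these compounds, the only single change beyond the scatter remains a 9.6-fold higher number from compound 2 to compound 3 (0.98 log units; beyond the scatter) on the saturated ring, and one step at each of the two places supports no general rule about them.

Still open, from the compounds shown here alone, is how this position responds to other groups, such as a carboxamide, a chlorine atom or a longer chain like ethyl. Methyl and cyano are the only two shown there. Also open, going by these compounds, is whether methyl and cyano would still read alike with the 1-hydroxy-1-methylethyl group of compound 3 in place of hydroxymethyl on the saturated ring.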